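This account rests on a few compounds, and the source may have more. Where it says the series, first, only, none or still open, it means among the compounds named here.

Cytotoxicity in an ADME assay on HUVEC cells (Homo sapiens) for cytotoxicity, read by MTT assay, with a stated time of 2 days (on this read-out higher numbers stand for weaker inhibition and lower numbers for stronger inhibition), values so far:

compound 1 `O/N=C1/C(c2c[nH]c3ccc(OCc4ccccc4)cc23)=Nc2ccc(OCc3ccccc3)cc21`: > 100000 nM
compound 2 `Fc1ccc2c(c1)/C(=N\OCc1ccccc1)C(c1c[nH]c3ccc(F)cc13)=N2`: > 100000 nM

Both shown values are limits of the assay and not numbers. Compound 1 gives only a limit in this assay. Compound 2 also stands at the limit, as in the limit of > 100000 nM in this assay, at which 2 of the 2 values shown sit. Compound 3 `Cc1ccc(CO/N=C2/C(c3c[nH]c4ccc(F)cc34)=Nc3ccc(F)cc32)cc1` is not yet measured; it differs from compound 2 by methyl in place of hydrogen on an aromatic carbon. With every shown value at the limit, no step beyond the scatter is expected in this assay, and the step of a number no higher from compound 2 to compound 3 (the limit leaves the size open) is the size expected. Compound 3 is estimated at 100000 nM, within 40000 nM to 300000 nM, most likely reported again only as a limit.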

Compound 3, half-maximal inhibitory concentration: > 100000 nM
Compound 3 gave a limit, no number; the forecaster's own chance of this, stated with the estimate: 85%; the middle value sits exactly at the limit.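

In this assay no step can be read between compound 2 and compound 3, as both give limits and not numbers: the limit of > 100000 nM in this assay, at which 3 of the 3 values shown sit. The compounds shown leave open whether 4-methylbenzyl in place of benzyl changes cytotoxicity at all.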